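Taking the chloro group off compound 1

The compounds below may be only part of what the source reports. "The series", "measured", "known", "first", "only" and "open" are said of these compounds alone.

Within the data shown here, in a functional assay on SNO cells (Homo sapiens) for cytotoxicity, read by XTT assay, with a stated time of 24 h (a higher number here means a weaker inhibitor, a lower number a stronger inhibitor), compound 1 `Cc1cc(Cl)c2c(c1O)C(=O)C=CC2=O` gives 9400 nM, the lowest number of the three measured so far. Compound 2 `CC(=O)Oc1c(C)cc(Cl)c2c1C(=O)C=CC2=O` gives 28600 nM, and compound 3 `CCOc1c(C)cc(Cl)c2c1C(=O)C=CC2=O` gives 37300 nM. Both differ from the first only on the oxygen of the hydroxy group. Acetyl there gives a 3.0-fold higher number from compound 1 to compound 2 (0.48 log units; beyond the scatter), and ethyl gives a 4.0-fold higher number from compound 1 to compound 3 (0.60 log units; beyond the scatter). Both steps are modest, and the two replacements do not separate, with a 1.3-fold higher number from compound 2 to compound 3 (0.12 log units; within the scatter).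

Compound 4 `Cc1ccc2c(c1O)C(=O)C=CC2=O` keeps the hydroxy group and instead has hydrogen in place of chloro on an aromatic carbon, para to a hydroxy group (hydrogen in place of chloro on an aromatic carbon). Among the measured compounds shown here, no measured step touches that carbon, so the oxygen steps offer only a rough sense of scale, and the data fix no direction. For the measured compounds named here, a small rise in the number is tentatively expected, with no step clearly beyond the scatter. The expected step is a 1.2-fold higher number from compound 1 to compound 4 (0.07 log units; within the scatter). For compound 4 the estimated value is 11000 nM, with an expected range of 4000 nM to 30000 nM.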

Compound 4, half-maximal inhibitory concentration: 19000 nM
Compound 4: the middle estimate sits 1.7-fold (0.24 log units) below what was measured; the measured number falls inside the stated range.
By their numbers in this assay, from the lowest: compound 1; then compounds 4, 2 and 3 (each within the scatter of the next).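

The carbon para to a hydroxy group turns out to matter in its own right: in this assay, hydrogen in place of chloro gives a 2.0-fold higher number from compound 1 to compound 4 (0.31 log units; beyond the scatter), a modest step but one that the oxygen steps could not have foretold, since none of them touched this carbon. Among these compounds, it also settles the direction the earlier compounds left unfixed, so that all three single changes from compound 1 now raise the number, whether made on the oxygen or on this aromatic carbon. Nothing available offers a reason for this step.

The compounds shown carry only chloro or hydrogen on this carbon, so it remains open how bromo, a methoxy group or an amine would read there. Also open, from the compounds shown here alone, is whether losing chloro would shift the number similarly with acetyl or ethyl on the oxygen.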